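This account rests on a few compounds, and the source may have more. Where it says the series, first, only, none or still open, it means among the compounds named here.

Compound 1, `Cc1ncc(S(=O)(=O)N(C)C)cc1C#Cc1cc(Cl)ccc1OCC(=O)O`, gives 41 nM in an assay on CHO cells for displacement of a labelled ligand from prostaglandin D2 receptor 2 (Homo sapiens), read by scintillation counting; a lower number here means a stronger inhibitor, a higher number a weaker inhibitor.
Compound 2, `CC(C)c1ccc(S(C)(=O)=O)cc1C#Cc1cc(C#N)ccc1OCC(=O)O`, gives 12 nM in this assay.
Compound 3, `CNS(=O)(=O)c1ccc(C)c(C#Cc2cc(Cl)ccc2OCC(=O)O)c1`, gives 10 nM in this assay.

Compound 3 stands at the lowest of the three numbers. Its nearest neighbour is compound 2, whose value lies within the scatter of that of compound 3, so the two cannot be told apart. Compound 1 lies beyond the scatter above compound 3. For the measured compounds named here, no pair of measured compounds differs in a single place, so nothing more than these values themselves can be said of any pair.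

Compound 4, `Cc1ccc(S(=O)(=O)N(C)CCN(C)C)cc1C#Cc1cc(Cl)ccc1OCC(=O)O`, shares the core of compound 3 and differs from it in one place: 2-(dimethylamino)ethyl in place of hydrogen on a sulfonamide nitrogen. The sulfonamide nitrogen that carries a hydrogen in compound 3 carries a 2-(dimethylamino)ethyl group in compound 4. Going by the values given here, no measured pair shows what such an addition on a sulfonamide nitrogen does, so the expectation rests on the values of compounds 1, 2 and 3 alone. In this assay a small step towards a somewhat higher number is expected, as a 1.6-fold higher number from compound 3 to compound 4 (0.20 log units; within the scatter), though a result within the scatter would not surprise. Compound 4 is therefore estimated at 16 nM, with a range from 5 nM to 50 nM.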

Compound 4, inhibition constant: 369 nM
For compound 4 the middle estimate is 23-fold (1.36 log units) below the measured one; the measured number lies above the stated range.
By their numbers in this assay, from the lowest: compounds 3 and 2 (each within the scatter of the next); then compound 1; then compound 4.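

On the sulfonamide nitrogen of compound 3, the hydrogen cannot be exchanged freely: in this assay, putting 2-(dimethylamino)ethyl in its place gives a 37-fold higher number from compound 3 to compound 4 (1.57 log units; beyond the scatter). For the compounds shown here, this is the first single-place change, and it shows that this position responds strongly to what it carries, which the separate values of the earlier compounds could not show. Nothing available here explains why the step is so large.

Going by these compounds, it remains open whether the higher number goes with the terminal dimethylamino group or with the chain that carries it, and a 2-methoxyethyl group on the same nitrogen would separate the two. Also open, on these data alone, is whether a plain ethyl group there would stay near the value of compound 3 (10 nM).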